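The compounds below may be only part of what the source reports. "The series", "measured", "known", "first", "only" and "open" are said of these compounds alone.

Of the compounds shown here, three sharing one core have been measured in an ADME assay on Huh-7 cells (Homo sapiens) for cytotoxicity; on this read-out higher numbers stand for lower toxicity in this test and lower numbers for higher toxicity in this test. Within the data shown here, compound 1 `CN1CCN(CCCNCc2cn(-c3ccc([N+](=O)[O-])cc3)nc2-c2ccc(OC(F)(F)F)cc2)CC1` gives 1600 nM, the only numeric value among them. Compound 2 `Cc1ccccc1-c1nn(-c2ccccc2Cl)cc1CNCCN1CCN(C)CC1` reaches only the limit of the test, > 20000 nM. Compound 3 `Cc1ccccc1-c1nn(-c2ccc(F)cc2F)cc1CN1CCC(N2CCCCC2)CC1` also stops at the limit, > 20000 nM. Compound 2 thus stands at the limit of > 20000 nM in this assay, at which 2 of the 3 values shown sit, and nothing numeric separates it from compound 3, while compound 1 lies clearly on the more toxic side. Compound 4 `CSc1ccc(-n2cc(CNCCN3CCN(C)CC3)c(-c3ccccc3C)n2)cc1` has not yet been tested; it differs from compound 2 in one place: 4-(methylsulfanyl)phenyl in place of 2-chlorophenyl on an aromatic nitrogen. Among the measured compounds shown here, no pair of measured compounds isolates this change, so its size is not known from the data. Because compound 2 already sits at the limit of > 20000 nM in this assay, at which 2 of the 3 values shown sit, any gain in that direction could not be read as a number. Compound 4 is expected to give 16000 nM, with a range from 5000 nM to 40000 nM. The expected step in this assay is an at least 1.2-fold lower number from compound 2 to compound 4 (0.09 log units; that floor lies within the scatter), not beyond the scatter.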

Compound 4, half-maximal cytotoxic concentration: 17000 nM
Compound 4: the middle estimate sits 1.1-fold (0.03 log units) below what was measured; measured number inside the range.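

In this assay, among these compounds, compound 4 gives 17000 nM, so a compound with 4-(methylsulfanyl)phenyl on this aromatic nitrogen gives a number inside the range of the test, which the earlier compounds with a 2-methylphenyl group did not do. Placing 4-(methylsulfanyl)phenyl in place of 2-chlorophenyl gives an at least 1.1-fold lower number from compound 2 to compound 4 (0.07 log units; that floor lies within the scatter), so the change can be read only as a floor, and that floor does not go beyond the usual scatter. The full size of the step stays unknown because compound 2 is held at a limit of the test: the limit of > 20000 nM in this assay, at which 2 of the 4 values shown sit.

The compounds shown leave open how a 4-methoxyphenyl or a 4-(methylsulfonyl)phenyl group on the same nitrogen would read in this assay. They also leave open whether the sulfur atom or the shift of the substituent on the phenyl ring matters more here.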